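The source may report more compounds than this note shows. Statements on the series, on what has been measured and on what is new or still open speak of the compounds shown alone.

Compounds measured in a functional assay for inhibition of sodium/hydrogen exchanger (Oryctolagus cuniculus); a lower number here means a stronger inhibitor, a higher number a weaker inhibitor:

compound 1 `Cc1cc(Cl)c(S(C)(=O)=O)cc1C(=O)N=C(N)N`: 25 nM
compound 2 `CS(=O)(=O)c1cc(C(=O)N=C(N)N)ccc1-n1ccnc1`: 150 nM
compound 3 `CS(=O)(=O)c1cc(C(=O)N=C(N)N)ccc1Oc1cccnc1`: 76 nM

Compound 3 holds the second highest of the three numbers in this assay. Its nearest neighbour is compound 2, and the step of a 2.0-fold lower number from compound 2 to compound 3 (0.30 log units; within the scatter) is within the scatter; compound 1 is furthest from it, with a number beyond the scatter below that of compound 3. Compound 4 `CS(=O)(=O)c1cc(C(=O)N=C(N)N)ccc1Cl` differs from compound 3 in one place: chloro in place of (pyridin-3-yl)oxy on an aromatic carbon. Going by the values given here, the only measured step at this position is the one from compound 2 to compound 3, and it was small. Compound 1 also carries chloro there and gives 25 nM, though it differs from compound 3 in a further group as well. The number for compound 4 is therefore expected to move down by a 1.9-fold lower number from compound 3 to compound 4 (0.28 log units; within the scatter). Compound 4 is estimated at 40 nM, with a range from 15 nM to 110 nM.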

Compound 4, half-maximal inhibitory concentration: 380 nM
The estimate for compound 4 lay 9.5-fold (0.98 log units) below the measured number; the whole stated range lies below it.
By their numbers in this assay, from the lowest: compound 1; then compounds 3 and 2 (each within the scatter of the next); then compound 4.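

Measured in this assay chloro ortho to a methylsulfonyl group gives a 5.0-fold higher number from compound 3 to compound 4 (0.70 log units; beyond the scatter) when it replaces (pyridin-3-yl)oxy, and a 2.5-fold higher number from compound 2 to compound 4 (0.40 log units; beyond the scatter) when it replaces 1H-imidazol-1-yl, so on this core both ring groups give lower numbers than chloro. The low number of compound 1 therefore does not come with chloro alone: hydrogen in place of methyl gives a 15-fold higher number from compound 1 to compound 4 (1.18 log units; beyond the scatter) with chloro kept. No measurement here accounts for these steps. The compounds leave open how an amine or a methoxy group would compare at this position, and whether methyl would lower the number with (pyridin-3-yl)oxy there.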